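Allyl in place of pyrazolyl on the amide nitrogen

The source may report more compounds than this note shows. Statements on the series, on what has been measured and on what is new or still open speak of the compounds shown alone.

Compound 1 `Cc1ccc(OCC(=O)N(Cc2cccs2)c2ccn(C)n2)cc1` is one of two measured compounds. In an assay on HEK293 cells for agonist activity at transient receptor potential cation channel subfamily M member 8 (Homo sapiens), read by fluorescence and calcium flux, with a stated time of 15 min (a lower number here means that less compound is needed, a higher number that more compound is needed for the effect), compound 1 gives 855 nM, the higher of the two numbers, while compound 2 `CCN(Cc1ccco1)C(=O)COc1ccc(C)cc1` gives 489 nM; the gap between them lies within the scatter. Compound 3 `C=CCN(Cc1cccs1)C(=O)COc1ccc(C)cc1` differs from compound 1 in one place: allyl in place of 1-methyl-1H-pyrazol-3-yl on an amide-type nitrogen. Among the compounds with values here, no measured pair shows this change, so the step in this assay can only be estimated. Because compound 2 gives 489 nM, a modest downward step is expected, a 1.9-fold lower number from compound 1 to compound 3 (0.28 log units; within the scatter), not clearly beyond the scatter. Compound 3 is estimated at 450 nM, with a range from 150 nM to 1400 nM.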

Compound 3, half-maximal effective concentration: 20 nM
Beside the measured number, compound 3's estimate is 23-fold (1.35 log units) above it, outside the stated range (below it).
By their numbers in this assay, from the lowest: compound 3; then compounds 2 and 1 (each within the scatter of the next).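

In this assay, allyl in place of 1-methyl-1H-pyrazol-3-yl on the amide-type nitrogen gives a 43-fold lower number from compound 1 to compound 3 (1.63 log units; beyond the scatter). This first matched step shows that the number is highly sensitive to the group at this position, and that a ring is not needed there for a low number. No measurement bears on why the step is so large. The compounds shown leave open whether the double bond of allyl matters, since a saturated propyl chain would test this. They also leave open whether a longer chain, such as butyl, or a phenyl ring would hold the low number.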